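The source may hold more compounds than are shown below. What is called first, only, known or untested is meant among the compounds shown, and "the series" means these compounds.

Measured compounds:
compound 1, `CCn1c(=O)[nH]c2c(cnn2-c2cccc(Cl)c2)c1=N`: 70%
compound 2, `Cn1c(=O)[nH]c2c(cnn2-c2ccccc2[N+](=O)[O-])c1=N`: 5%

In an assay on membranes from brain for binding affinity to adenosine receptor A1 (Rattus norvegicus), read by radioligand binding, tested at 20 uM (on this read-out higher numbers stand for more inhibition at the one concentration tested (going by the name of the read-out) and lower numbers for less inhibition), compound 1 gives 70%, the higher of the two numbers recorded so far. Compound 2 gives 5% in this assay, a gap beyond the scatter; the two structures differ in more than one place, so nothing beyond the two values themselves is read into that gap. The next compound, compound 3 `CCCn1c(=O)[nH]c2c(cnn2-c2cccc(Cl)c2)c1=N`, is not yet measured. It differs from compound 1 by methyl in place of hydrogen on a saturated chain carbon, two bonds along the chain from an aromatic nitrogen; cut one bond further out, the same difference reads ethyl to propyl on the chain carried by the core of compound 1. Among the measured compounds shown here, no single-change step has been recorded, so the expected step is small, with no clear direction, and none beyond the scatter. Compound 3 is expected to give 65% in this assay, within 40% to 85%. The step of a number 5 percentage points lower from compound 1 to compound 3 (within the scatter) is estimated to stay within the scatter.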

Compound 3, a percentage reported as inhibition, at one concentration (the size of the read-out at that concentration, not a potency): 68%
Estimate against measurement, compound 3: 3 percentage points below; measured number inside the range.
By their numbers in this assay, from the lowest: compound 2; then compounds 3 and 1 (each within the scatter of the next).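

In this assay, among the compounds shown here, the first single-change step reads a number 2 percentage points lower from compound 1 to compound 3 (within the scatter) for methyl in place of hydrogen on a saturated chain carbon, two bonds along the chain from an aromatic nitrogen. On the core of compound 1, the chain at this position can therefore read ethyl or propyl with no step beyond the scatter at the one concentration tested. No supporting data bear on why this change leaves the read-out within the scatter.

As far as these compounds go, whether this holds for a longer chain such as butyl, or for a chain ending in an amine or a carboxylic acid, remains open. Also open, from the compounds shown here alone, is whether the same change would give a similar step on a core carrying a different aryl group, and single-concentration numbers leave potency itself unresolved.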